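Compound 3 to compound 4: exchanging the phenyl group

The compounds below may be only part of what the source reports. "The series", "measured", "known", "first", "only" and "open" are said of these compounds alone.

Of the compounds shown here, three with a shared core have been read in a physicochemical assay for solubility, in phosphate buffer, measured as kinetic solubility, at pH 7.4; a lower number here means a less soluble compound, a higher number a more soluble compound: compound 1 `Cc1oc(-c2c(Cl)cccc2Cl)nc1CN1CCC(C(=O)NCCCN2C[C@H](C)C[C@H](C)C2)CC1`, compound 2 `Cc1oc(-c2c(Cl)cccc2C(F)(F)F)nc1CN1CCC(C(=O)NCCCN2C[C@H](C)C[C@H](C)C2)CC1` and compound 3 `Cc1cccc(-c2nc(CN3CCC(C(=O)NCCCN4C[C@H](C)C[C@H](C)C4)CC3)c(C)o2)c1`. Compound 1 gives > 77 ug/mL, which is a limit of the assay and not a number. Going by the values given here, compound 2 gives 65.1 ug/mL, the only actual number in the set. Compound 3 gives > 69 ug/mL, which is also a limit and not a number.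

Compound 4 `COc1cccc(Cl)c1-c1nc(CN2CCC(C(=O)NCCCN3C[C@H](C)C[C@H](C)C3)CC2)c(C)o1` carries 2-chloro-6-methoxyphenyl in place of the 3-methylphenyl of compound 3, on an aromatic carbon (2-chloro-6-methoxyphenyl in place of 3-methylphenyl on an aromatic carbon).

Among the compounds with values here, three measured steps bear on this change, all at the same phenyl group. Trifluoromethyl in place of chloro gave an at least 1.1-fold lower number from compound 1 to compound 2 (0.07 log units; that floor lies within the scatter), a floor within the scatter. 3-Methylphenyl in place of 2-chloro-6-(trifluoromethyl)phenyl gave an at least 1.0-fold higher number from compound 2 to compound 3 (0.02 log units; that floor lies within the scatter), again a floor within the scatter. 3-Methylphenyl in place of 2,6-dichlorophenyl gave a step that the two limits leave unreadable from compound 1 to compound 3.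

No readable step goes beyond the scatter, so no step beyond the scatter is expected in this assay. Compound 4 is expected to read close to compound 2 at 65.1 ug/mL. Compound 4 could instead reach a limit of the assay. The expected change is a step that the limit leaves unreadable from compound 3 to compound 4. For compound 4 the estimate is 70 ug/mL, with an expected range of 50 ug/mL to 80 ug/mL.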

Compound 4, solubility: > 76 ug/mL
Compound 4 was reported as a limit (the forecaster's own chance of this, stated with the estimate: 55%); middle value at least 1.0-fold (0.03 log units) from the limit.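

In this assay compound 4 gives > 76 ug/mL, a limit of the assay and not a number. The 2-chloro-6-methoxyphenyl group therefore stands with the 2,6-dichlorophenyl group of compound 1 and the 3-methylphenyl group of compound 3, as a third group at this position that is read only as a limit. Methoxy in place of trifluoromethyl gives an at least 1.1-fold higher number from compound 2 to compound 4 (0.06 log units; that floor lies within the scatter), so this position has still produced no step beyond the scatter, while the other two steps to compound 4, from compound 1 and from compound 3, join limit to limit and cannot be read.

As far as these compounds go, with three of the four compounds reported as limits, the size of any real difference among the 2-chloro-6-methoxyphenyl, 2,6-dichlorophenyl and 3-methylphenyl groups stays open. Also open, from the compounds shown here alone, is how an amine or a carboxylic acid on the phenyl group would read in this assay, and whether either would give a step beyond the scatter.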